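Acetyl replacement on the methoxy-substituted series: tolerance estimate

This account rests on a few compounds, and the source may have more. Where it says the series, first, only, none or still open, it means among the compounds named here.

Measured in an ADME assay on BHK-21 cells (Mesocricetus auratus) for cytotoxicity, read by MTT assay; a higher number here means that more compound is tolerated, a lower number that less compound is tolerated:
- compound 1 `COc1ccc(-c2nc3cc(C(C)=O)ccc3n2C2CCCCC2)cc1`: > 100000 nM, a limit of the assay
- compound 2 `COc1ccc(-c2nc3cc(C(C)=O)ccc3n2C2CCCCC2)c(OC)c1`: 8500 nM

Going by the values given here, compound 2 holds the only actual number so far, since the other entry is a limit. The next compound is compound 3 `COc1ccc(-c2nc3cc(/C(C)=N/NC(N)=O)ccc3n2C2CCCCC2)c(OC)c1`, with the change (a group of 7 heavy atoms (3 carbon, 3 nitrogen, 1 oxygen; no ring) in place of a group of 3 heavy atoms (2 carbon, 1 oxygen; no ring), on an aromatic carbon), a larger group with no ring in place of acetyl on an aromatic carbon. One measured step exists, an at least 11-fold lower number from compound 1 to compound 2 (1.07 log units; beyond the scatter). It is large, but it comes from methoxy in place of hydrogen, a different change that leaves the acetyl untouched. It therefore gives no guide to the size or direction of this replacement, and no step beyond the scatter is expected in this assay, though with wide uncertainty. The expected step is a 1.2-fold higher number from compound 2 to compound 3 (0.07 log units; within the scatter). For compound 3 the estimate is 10000 nM, with an expected range of 3000 nM to 50000 nM.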

Compound 3, half-maximal cytotoxic concentration: 19000 nM
Estimate against measurement, compound 3: 1.9-fold (0.28 log units) below; low and high end bracket the measured number.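

Going by these compounds alone, the acetyl position gives the first readable information on this part of the series. In this assay, the larger group with no ring in place of acetyl gives a 2.2-fold higher number from compound 2 to compound 3 (0.35 log units; beyond the scatter), a modest move towards more compound being tolerated, with the added methoxy of compound 2 kept in place. The position, on an aromatic carbon of the six-membered aromatic ring of carbon only, therefore takes a group with more heavy atoms and with hydrogen-bond donors, where acetyl has none, without a drop in this number.

On these data alone, whether the step holds without the added methoxy stays open, as does the outcome for an amine or a carboxylic acid at this position. Compound 1, which lacks that methoxy, stands only as a limit, which restricts any comparison with it: the limit of > 100000 nM in this assay, at which 1 of the 3 values shown sits.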